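A Methyl on the Aromatic Ring of Compound 1

The source may report more compounds than this note shows. Statements on the series, on what has been measured and on what is new or still open speak of the compounds shown alone.

Compound 1 `CC1CCCN1C1CCN(c2ccc(NC(=O)C3CC3)cc2)C1` gives 9.7 nM in an assay on CHO cells for displacement of a labelled ligand from histamine receptor H3 (Macaca mulatta); a lower number here means a stronger inhibitor, a higher number a weaker inhibitor. Among the three measured compounds it holds the second highest number. Its nearest neighbour is compound 3 `CC1CCCN1C1CCN(c2ccc(NC(=O)C3CCCO3)cc2)C1`, which in this assay gives 8.7 nM; the step of a 1.1-fold lower number from compound 1 to compound 3 (0.05 log units; within the scatter). The furthest is compound 2 `CC(=O)N1CCCC1C(=O)Nc1ccc(N2CCC(N3CCCC3C)C2)cc1`, which gives 14.1 nM; the step of a 1.5-fold higher number from compound 1 to compound 2 (0.16 log units; within the scatter). Between those two, the step of a 1.6-fold lower number from compound 2 to compound 3 (0.21 log units; within the scatter). All three measured compounds thus sit within the scatter of one another.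

Compound 4 `Cc1cc(N2CCC(N3CCCC3C)C2)ccc1NC(=O)C1CC1` differs from compound 1 by methyl in place of hydrogen on an aromatic carbon. Going by the values given here, none of the measured steps bears directly on this change: each of them alters only the group on the carbonyl carbon, and the aromatic ring carrying the amide is unchanged across compounds 1, 2 and 3. What the measured steps do show is that every variation tried so far has stayed within the scatter. Among the compounds with values here, on that basis no step beyond the scatter is expected from compound 1 to compound 4, and the estimate carries a wide range because no step on the ring itself has been measured. The expected number for compound 4 is 12 nM, with a range from 4 nM to 35 nM. This estimate means a step of a 1.2-fold higher number from compound 1 to compound 4 (0.09 log units; within the scatter).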

Compound 4, inhibition constant: 9.6 nM
Estimate against measurement, compound 4: 1.3-fold (0.10 log units) above, and the stated range covers the measured number.
By their numbers in this assay, from the lowest: compounds 3, 4, 1 and 2 (each within the scatter of the next).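

In this assay, compounds 1, 2 and 3 differ only in the group on the carbonyl carbon, whereas compound 4 brings a change to the aromatic ring itself: methyl in place of hydrogen on an aromatic carbon, ortho to a (cyclopropylcarbonyl)amino group, gives the step of a 1.0-fold lower number from compound 1 to compound 4 (0.00 log units; within the scatter). This position therefore accepts a methyl group, a single carbon with no ring and no hydrogen-bond donors or acceptors, without a step beyond the scatter, at least with cyclopropyl on the carbonyl carbon. No measurement shown here explains this result, and the single step speaks only for methyl at this one place.

The compounds shown leave open whether an ethyl group, a methoxy group, a chlorine atom or an amine on this same aromatic carbon would also stay within the scatter, and whether a methyl group elsewhere on the ring would do so. They also leave open whether this methyl group would give the same result alongside the oxolan-2-yl group of compound 3 or the 1-acetylpyrrolidin-2-yl group of compound 2.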